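Rearranged chlorofluorophenyl group in compound 4

The compounds below may be only part of what the source reports. "The series", "measured", "known", "first", "only" and "open" are said of these compounds alone.

Values in an ADME assay on Vero cells (Chlorocebus sabaeus) for cytotoxicity, read by MTT assay, with a stated time of 72 h; on this read-out lower numbers stand for higher toxicity in this test and higher numbers for lower toxicity in this test:
- compound 1 `C[C@]1(CN2CCc3nc(C4CCOCC4)ccc3C2)Cn2cc([N+](=O)[O-])nc2O1`: "not determined" (no result reported)
- compound 2 `C[C@]1(CN2CCc3nc(-c4cccc(F)c4)ccc3C2)Cn2cc([N+](=O)[O-])nc2O1`: > 32 ug/mL
- compound 3 `C[C@]1(CN2CCc3nc(-c4cc(F)ccc4Cl)ccc3C2)Cn2cc([N+](=O)[O-])nc2O1`: > 32 ug/mL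

Compound 3 gives > 32 ug/mL, which is a limit and not a number. Compound 2 also gives a limit, > 32 ug/mL. Among the measured compounds shown here, the one measured step is a step that the two limits leave unreadable from compound 2 to compound 3, with chloro in place of hydrogen, so no size can be taken from it. Compound 4 `C[C@]1(CN2CCc3nc(-c4cccc(Cl)c4F)ccc3C2)Cn2cc([N+](=O)[O-])nc2O1` differs from compound 3 by 3-chloro-2-fluorophenyl in place of 2-chloro-5-fluorophenyl on an aromatic carbon. The expectation rests on compound 3, whose > 32 ug/mL is a limit, and on (the limit of > 32 ug/mL in this assay, at which 2 of the 3 values shown sit). The estimated change is a step that the limit leaves unreadable from compound 3 to compound 4, expected to stay within the scatter and without a direction. For compound 4 the estimate is 35 ug/mL, with an expected range of 18 ug/mL to 64 ug/mL.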

Compound 4, half-maximal cytotoxic concentration: > 32 ug/mL
Compound 4: only a limit was reported (the forecaster's own chance of this, stated with the estimate: 85%); the middle value lies beyond the limit too.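

In this assay compound 4 gives > 32 ug/mL, a limit and not a number, so its steps from compound 2 and compound 3 cannot be read. As far as these compounds go, whether the aryl substituents differ at all in this read-out remains open.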